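The source may hold more compounds than are shown below. What is called first, only, known or untested is meant among the compounds shown, and "the series" means these compounds.

In a functional assay on MCF7 cells (Homo sapiens) for antiproliferative activity, read by MTT assay, with a stated time of 72 h (on this read-out lower numbers stand for stronger inhibition and higher numbers for weaker inhibition), compound 1 (`C#CCSc1nc(Sc2nnnn2CCN(C)C)c(C#N)c(-c2ccc(Cl)cc2)n1`) gives 6180 nM. In the same test, compound 2 (`C#CCSc1nc(Sc2nccs2)c(C#N)c(-c2ccc(Br)cc2)n1`) gives 11600 nM, and the numbers for these two compounds lie within the usual scatter of each other, so neither can be ranked over the other. Compound 3 (`C#CCSc1nc(Sc2nc[nH]n2)c(C#N)c(-c2cc(OC)c(OC)c(OC)c2)n1`) reads > 20000 nM, which is a limit of the assay and not a number. Within the data shown here, compound 2 therefore stands level with compound 1, and it is one of only two compounds with a measured number.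

Compound 4 (`C#CCSc1nc(Sc2nccs2)c(C#N)c(-c2ccc(Cl)cc2)n1`) departs from compound 2 in a single place: chloro in place of bromo on an aromatic carbon. This is chloro in place of bromo on an aromatic carbon, para to a large group, so that 4-bromophenyl becomes 4-chlorophenyl. No measured pair among these compounds shows this change on its own. Among the measured compounds shown here, the only related guide is compound 1, which also carries the 4-chlorophenyl group on a differently substituted core and gives 6180 nM.

In this assay no shift beyond the scatter is expected for this exchange. The estimated step of a 1.2-fold lower number from compound 2 to compound 4 (0.06 log units; within the scatter) is expected to be small. Compound 4 is estimated at 10000 nM, with an expected range of 5000 nM to 20000 nM.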

Compound 4, half-maximal inhibitory concentration: 3230 nM
Compound 4: the middle estimate sits 3.1-fold (0.49 log units) above what was measured; measured number outside the range, below it.
By their numbers in this assay, from the lowest: compounds 4, 1 and 2 (each within the scatter of the next, the first and the last beyond it). At a limit, above all of these: compound 3.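

In this assay, among these compounds, the exchange of 4-bromophenyl for 4-chlorophenyl, with the 1,3-thiazol-2-yl group on sulfur held fixed, gives the only measured pair for this position, and it reads a 3.6-fold lower number from compound 2 to compound 4 (0.56 log units; beyond the scatter) as a modest step. Among the compounds shown here, replacing one halogen with another on this aromatic carbon, para to a large group, therefore changes the number by more than the scatter in this one pair, which the earlier compounds could not show. With 4-chlorophenyl held fixed, the change on sulfur reads a 1.9-fold lower number from compound 1 to compound 4 (0.28 log units; within the scatter) so 1,3-thiazol-2-yl and 1-(2-(dimethylamino)ethyl)-1H-tetrazol-5-yl cannot be ranked against each other in this pair.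

The compounds shown offer no measured property that bears on the step from bromo to chloro. From the compounds shown here alone, it remains open whether the same step would appear with another group on sulfur, and how fluoro, methyl or methoxy would read in place of chloro on this aromatic carbon.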